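Side-chain exchange from compound 3 to compound 4

The source may hold more compounds than are shown below. What is called first, only, known or untested is meant among the compounds shown, and "the series" means these compounds.

- compound 1 `O=C1c2c[n+]([O-])c3ccccc3c2C(=O)c2c1c1ccccc1n2CCCCn1ccnc1`: 170 nM
- compound 2 `O=C1c2c[n+]([O-])c3ccccc3c2C(=O)c2c1c1ccccc1n2Cc1cn(C[C@H](O)CO)nn1`: 1030 nM
- compound 3 `CN1CCN(CCCCn2c3c(c4ccccc42)C(=O)c2c[n+]([O-])c4ccccc4c2C3=O)CC1`: 90 nM

In a functional assay on A549 cells (Homo sapiens) for cytotoxicity, read by MTT assay, with a stated time of 72 h (a higher number here means a weaker inhibitor, a lower number a stronger inhibitor), compound 3 stands level with compound 1, with a 1.9-fold lower number from compound 1 to compound 3 (0.28 log units; within the scatter), and clear of compound 2, with an 11-fold lower number from compound 2 to compound 3 (1.06 log units; beyond the scatter).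

Compound 4 `O=C1c2c[n+]([O-])c3ccccc3c2C(=O)c2c1c1ccccc1n2CCN1CCCC1` differs from compound 3 thus: pyrrolidin-1-yl in place of 2-(4-methylpiperazin-1-yl)ethyl on a saturated chain carbon, two bonds along the chain from an aromatic nitrogen. Among the compounds with values here, no measured step covers this exchange directly. The closest is a 1.9-fold lower number from compound 1 to compound 3 (0.28 log units; within the scatter), also an exchange of one ring for another on a saturated chain. Both steps beyond the scatter, a 6.1-fold higher number from compound 1 to compound 2 (0.78 log units; beyond the scatter) and an 11-fold lower number from compound 2 to compound 3 (1.06 log units; beyond the scatter), involve compound 2, whose 1-(2,3-dihydroxypropyl)-1H-1,2,3-triazol-4-yl group is absent from compound 4. The expected result in this assay is a 1.4-fold higher number from compound 3 to compound 4 (0.16 log units; within the scatter), so no step beyond the scatter is expected. Compound 4 is estimated at 130 nM, with an expected range of 40 nM to 400 nM.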

Compound 4, half-maximal inhibitory concentration: 410 nM
Estimate against measurement, compound 4: 3.2-fold (0.50 log units) below, outside the stated range (above it).
By their numbers in this assay, from the lowest: compounds 3 and 1 (each within the scatter of the next); then compound 4; then compound 2.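

Among the side chains without a triazole, this position is not flat in this assay: moving to 2-(pyrrolidin-1-yl)ethyl gives a 4.6-fold higher number from compound 3 to compound 4 (0.66 log units; beyond the scatter), and a 2.4-fold higher number from compound 1 to compound 4 (0.38 log units; beyond the scatter). The same side chain still stays clear of the 1-(2,3-dihydroxypropyl)-1H-1,2,3-triazol-4-yl group on a one-carbon link, with a 2.5-fold lower number from compound 2 to compound 4 (0.40 log units; beyond the scatter). No measurement at hand accounts for these shifts.

On these data alone, compound 4 changes ring and chain length together, so the share of each remains open. A 4-(pyrrolidin-1-yl)butyl chain and a 2-(4-methylpiperazin-1-yl)ethyl chain would separate the two.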